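The source may hold more compounds than are shown below. What is called first, only, known or untested is meant among the compounds shown, and "the series" means these compounds.

Measured in an in vitro functional assay on HEK285-7 cells for antagonist activity at prostaglandin D2 receptor 2 (Homo sapiens), read by BRET and beta-arrestin recruitment; a higher number here means a larger maximal response, a lower number a smaller maximal response:

Compound 1, `O=C(O)Cc1sc(C(c2ccc(F)cc2)c2ccc(F)cc2)nc1-c1cc(F)nc(F)c1`, gives 80%.
Compound 2, `O=C(O)Cc1sc(C(c2ccc(F)cc2)c2ccc(F)cc2)nc1-c1cc(F)cc(F)c1`, gives 80%.
Compound 3, `O=C(O)Cc1sc(C(c2ccc(F)cc2)c2ccc(F)cc2)nc1-c1ccccc1`, gives 80%.

The three compounds share one core and differ only in the aromatic group attached to it. Compound 3 stands level with the other two: no change at the digits printed from compound 1 to compound 3 (within the scatter) and no change at the digits printed from compound 2 to compound 3 (within the scatter), and likewise no change at the digits printed from compound 1 to compound 2 (within the scatter). Every exchange of this aromatic group seen so far has left the maximal response where it was.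

Compound 4, `N#Cc1cc(-c2nc(C(c3ccc(F)cc3)c3ccc(F)cc3)sc2CC(=O)O)ccc1F`, is the next member of the series. Its change from compound 3 is 3-cyano-4-fluorophenyl in place of phenyl on an aromatic carbon. This is again an exchange of the same aromatic group on the same carbon, so all three measured steps bear on it. They were all flat, and in this assay the expectation is therefore no step beyond the scatter, no change at the digits printed from compound 3 to compound 4 (within the scatter). The nitrile is new to the series, so this expectation rests on the pattern of the flat steps alone. For compound 4 the estimate is 80%, with a range from 65% to 95%.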

Compound 4, largest response reached (reported as efficacy), in percent of the reference or control that the assay uses: 80%
The estimate for compound 4 equals the measured number at the digits printed, and the stated range covers the measured number.
By their numbers in this assay, from the lowest: compounds 1, 2, 3 and 4 (each within the scatter of the next).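

In this assay, for the compounds shown here, this position also accepts 3-cyano-4-fluorophenyl, the first group here to carry a nitrile, with no change at the digits printed from compound 3 to compound 4 (within the scatter) when it replaces plain phenyl. Set against the two other substituted rings, it shows no change at the digits printed from compound 2 to compound 4 (within the scatter) and no change at the digits printed from compound 1 to compound 4 (within the scatter), so across these four compounds no exchange at this carbon moves the maximal response, and none goes against that pattern. Nothing measured here accounts for this flat result.

All four groups are six-membered aromatic rings, which leaves open whether the same holds for a quite different group on this carbon, such as an amine, a methyl group or a saturated cyclohexyl ring. Maximal response is also the only read-out shown, so how much of each compound is needed to reach it remains unknown.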